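Extending the side chain of compound 1 toward compound 4

The source may report more compounds than this note shows. Statements on the series, on what has been measured and on what is new or still open speak of the compounds shown alone.

Compound 1 `O=C(NCc1ccc(F)cc1)c1nc(Br)c2cccnc2c1NCc1ccccc1` carries the shared core with a benzylamino group. In a functional assay on HCT-116 cells (Homo sapiens) for cytotoxicity, read by MTT assay, with a stated time of 72 h (on this read-out higher numbers stand for weaker inhibition and lower numbers for stronger inhibition), compound 1 gives > 20000 nM, which is a limit of the assay and not a number. Compound 2 `CS(=O)(=O)Oc1c(C(=O)NCc2ccc(F)cc2)nc(Br)c2cccnc12` in this assay gives > 20000 nM, likewise a limit. Compound 3 `C[C@@H](Nc1c(C(=O)NCc2ccc(F)cc2)nc(Br)c2cccnc12)c1ccccc1` in this assay gives > 20000 nM, again a limit. Three steps connect these compounds: a step that the two limits leave unreadable from compound 1 to compound 2, a step that the two limits leave unreadable from compound 1 to compound 3 and a step that the two limits leave unreadable from compound 2 to compound 3. None of them has a readable size because of the limit of > 20000 nM in this assay, at which 3 of the 3 values shown sit. So far nothing within the series separates one compound from another.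

Compound 4 `O=C(NCCCNc1c(C(=O)NCc2ccc(F)cc2)nc(Br)c2cccnc12)c1ccccc1` comes next. Against compound 1 the change is 2-benzamidoethyl in place of phenyl on a saturated chain carbon bound to a nitrogen on an aromatic ring. The nearest measured comparison is the step from compound 1 to compound 3, at the same saturated chain carbon bound to a nitrogen on an aromatic ring, but its size is not readable. Among the measured compounds shown here, no step therefore gives a direction or a size for what this assay should show for compound 4. With every measured compound sitting at the limit, the expectation for compound 4 is that it stays near that limit, estimated at 30000 nM with a range from 8000 nM to 100000 nM. The estimated step that the limit leaves unreadable from compound 1 to compound 4 is therefore expected to be none beyond the scatter.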

Compound 4, half-maximal inhibitory concentration: > 10000 nM
Compound 4: a limit, no number; the forecaster's own chance of this, stated with the estimate: 75%; the middle value lies beyond the limit too.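

Compound 4 gives > 10000 nM in this assay, a limit of the assay and not a number. Compound 1 also sits at a limit, so the step between compound 1 and compound 4 cannot be read. The compounds shown leave open whether any change on the shared core brings a measurable value in this assay.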